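Swapping the aryl group on a shared core

The source may hold more compounds than are shown below. What is called first, only, known or untested is meant among the compounds shown, and "the series" means these compounds.

Two measured compounds share one core and differ only in the aromatic group attached to it. Compound 1 `FC(F)(F)Oc1ccc(-c2cc(COc3ccccc3-c3nc4ccccc4s3)on2)cc1` gives 19900 nM in a functional assay on COLO 205 cells (Homo sapiens) for cytotoxicity, read by MTT assay, with a stated time of 24 h; on this read-out higher numbers stand for weaker inhibition and lower numbers for stronger inhibition. Compound 2 `Fc1ccccc1-c1cc(COc2ccccc2-c2nc3ccccc3s2)on1` gives 18300 nM in this assay. Compound 2 holds the lowest of the two numbers shown, and compound 1 is its nearest neighbour. The step of a 1.1-fold lower number from compound 1 to compound 2 (0.04 log units; within the scatter) lies within the scatter, so these two numbers cannot be distinguished on this read-out.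

Compound 3 `COc1ccc(-c2cc(COc3ccccc3-c3nc4ccccc4s3)on2)cc1` has not yet been measured. It differs from compound 2 in one place: 4-methoxyphenyl in place of 2-fluorophenyl on an aromatic carbon. Among the compounds with values here, only one measured step bears on this change, a 1.1-fold lower number from compound 1 to compound 2 (0.04 log units; within the scatter), which altered the same aromatic group and produced nothing beyond the scatter. No step beyond the scatter is therefore expected here either, and the estimated step is a 1.0-fold lower number from compound 2 to compound 3 (0.01 log units; within the scatter). Compound 3 is expected to give about 18000 nM in this assay, with a range from 7000 nM to 45000 nM.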

Compound 3, half-maximal inhibitory concentration: 20700 nM
Estimate against measurement, compound 3: 1.2-fold (0.06 log units) below; low and high end bracket the measured number.
By their numbers in this assay, from the lowest: compounds 2, 1 and 3 (each within the scatter of the next).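

Putting 4-methoxyphenyl in place of 2-fluorophenyl on the aromatic carbon next to the ring nitrogen gives a 1.1-fold higher number from compound 2 to compound 3 (0.05 log units; within the scatter), so a third substituted phenyl group at this position leaves this assay without a step beyond the scatter. Methyl in place of trifluoromethyl on the oxygen on the aromatic ring gives a 1.0-fold higher number from compound 1 to compound 3 (0.02 log units; within the scatter), which shows that this exchange, confined to the group on that oxygen, also stays within the scatter. Nothing measured here offers a reason why these numbers stay so close.

All the groups shown at this position are phenyl rings with no net charge. On these data alone, whether an amine or a carboxylic acid on that phenyl ring, or a saturated cyclohexyl ring in its place, would move the number beyond the scatter remains open.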